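This account rests on a few compounds, and the source may have more. Where it says the series, first, only, none or still open, it means among the compounds named here.

Measured so far:
compound 1 `C=CCOc1c(C)c(C)c2c(c1C)CCC(C)(COc1ccc(/C=C3\SC(=O)NC3=O)cc1)O2`: 2%
compound 2 `C=CCOc1c(C)c(C)c2c(c1C)CCC(C)(COc1ccc(/C=C3\SC(=O)NC3=O)cc1C)O2`: 8%

In a functional assay on MCF7 cells (Homo sapiens), tested at 7.5 uM (a lower number here means a stronger effect, a higher number a weaker effect of the compound at the concentration tested), compound 1 gives 2%, the lower of the two numbers shown, while compound 2 gives 8%; the step of a number 6 percentage points higher from compound 1 to compound 2 (within the scatter) stays within the scatter, so the two compounds sit side by side. Compound 3 `Cc1c(C)c2c(c(C)c1OC(=O)CCC(=O)O)CCC(C)(COc1ccc(/C=C3\SC(=O)NC3=O)cc1)O2` differs from compound 1 in one place: (2-carboxyethyl)carbonyl in place of allyl on an oxygen on an aromatic ring. Among the compounds with values here, no measured step touches this oxygen; the only known step concerns a methyl on an aromatic carbon, so it offers no direct guide. The step of a number 8 percentage points higher from compound 1 to compound 3 (within the scatter) is therefore expected to be modest. Compound 3 is estimated at 10%, within a range from 0% to 40%.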

Compound 3, a percentage reported as activity, at one concentration (the size of the read-out at that concentration, not a potency): 76%
For compound 3 the middle estimate is 66 percentage points below the measured one; the measured number lies above the stated range.
By their numbers in this assay, from the lowest: compounds 1 and 2 (each within the scatter of the next); then compound 3.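

In this assay the swap of allyl for (2-carboxyethyl)carbonyl on the oxygen gives a number 74 percentage points higher from compound 1 to compound 3 (beyond the scatter) and so shows that the read-out responds strongly to the group on this oxygen. The methyl change on the aromatic carbon, by contrast, gave a number 6 percentage points higher from compound 1 to compound 2 (within the scatter) and showed no such sensitivity. Nothing available here explains the size of the new step.

Still open, from the compounds shown here alone, is which part of the (2-carboxyethyl)carbonyl group matters. Going by these compounds, how a small acetyl group, a free hydroxyl or a longer alkyl chain on this oxygen would read also remains unknown.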